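The compounds below may be only part of what the source reports. "The series", "measured", "known", "first", "only" and "open" are said of these compounds alone.

Measured so far:
compound 1 `COC(=O)N[C@H](C(=O)N1CCC[C@H]1C(=O)Nc1ccc([C@@H]2CC[C@@H](c3ccc(NC(=O)[C@@H]4CCCN4C(=O)[C@@H](NC(=O)OC)C(C)C)cc3)N2c2ccc([Si](C)(C)C)cc2)cc1)C(C)C`: 93.3%
compound 2 `CC[Si](CC)(CC)c1ccc(N2[C@H](c3ccc(NC(=O)[C@@H]4CCCN4C(=O)[C@@H](NC(=O)OC)C(C)C)cc3)CC[C@H]2c2ccc(NC(=O)[C@@H]3CCCN3C(=O)[C@@H](NC(=O)OC)C(C)C)cc2)cc1`: 92.7%

In an ADME assay on microsomes from liver (Mus musculus) for metabolic stability, read by HPLC, using NADPH, with stated times of 5 min and 60 min, tested at 0.2 uM (a higher number here means that more of the compound is left, a lower number that less of the compound is left), compound 1 gives 93.3% and compound 2 gives 92.7%; the step is a number 0.6 percentage points lower from compound 1 to compound 2 (within the scatter), so compound 1 holds the top number only by a margin within the scatter. Compound 3 `COC(=O)N[C@H](C(=O)N1CCC[C@H]1C(=O)Nc1ccc([C@@H]2CC[C@@H](c3ccc(NC(=O)[C@@H]4CCCN4C(=O)[C@@H](NC(=O)OC)C(C)C)cc3)N2c2ccc([Si](C)(C)C(C)(C)C)cc2)cc1)C(C)C` is not yet measured. It differs from compound 1 by tert-butyl in place of methyl on a silicon. Among the compounds with values here, the single step that bears on it, a number 0.6 percentage points lower from compound 1 to compound 2 (within the scatter), also enlarged the groups on the silicon and stayed within the scatter, so no step beyond the scatter is expected in this assay. Compound 3 is estimated at 92%, with an expected range of 80% to 99%, an expected step of a number 1.3 percentage points lower from compound 1 to compound 3 (within the scatter).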

Compound 3, percent of the compound remaining: 92.1%
Compound 3: middle estimate off by 0.1 percentage points, on the low side; low and high end bracket the measured number.
By their numbers in this assay, from the lowest: compounds 3, 2 and 1 (each within the scatter of the next).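

In this assay, tert-butyl in place of methyl on a silicon gives a number 1.2 percentage points lower from compound 1 to compound 3 (within the scatter), and the exchange of one silicon group for another of the same heavy-atom count gives a number 0.6 percentage points lower from compound 2 to compound 3 (within the scatter), both within the scatter. This position on the silicon therefore carries tert-butyl, as well as the groups seen earlier, with no step beyond the scatter. Nothing measured here explains this reading.

Still open, on these data alone, is whether a phenyl or an amine-bearing chain on the silicon would move the number beyond the scatter. Also open, as far as these compounds go, is what a plain tert-butyl on the aromatic carbon, with no silicon, would give.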